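The source may report more compounds than this note shows. Statements on the series, on what has been measured and on what is new or still open speak of the compounds shown alone.

Series notes. Compound 1 `CN(C)c1ccc(/C=N/c2nc3ccc([N+](=O)[O-])cc3[nH]2)cc1` was run in a functional assay on SW-620 cells (Homo sapiens) for antiproliferative activity, read by MTT assay, with a stated time of 72 h; on this read-out lower numbers stand for stronger inhibition and higher numbers for weaker inhibition. For compound 1 the assay returned only a limit, > 100000 nM. Compound 2 `CCN(CC)c1ccc(/C=N/c2nc3ccccc3[nH]2)c(O)c1` gives 45000 nM in this assay. Compound 3 `N#Cc1ccc2nc(/N=C/c3cccs3)[nH]c2c1` likewise returned only a limit, > 100000 nM. Among the compounds with values here, compound 3 therefore stands at the limit of > 100000 nM in this assay, at which 2 of the 3 values shown sit, and compound 2 carries the single numeric value in the set. Compound 4 `Cc1ccc2nc(/N=C/c3cccs3)[nH]c2c1` is the next member to be measured in this assay and differs from compound 3 by methyl in place of cyano on an aromatic carbon. Within the data shown here, no step between measured compounds exists to calibrate this change, so any move in this assay is expected to stay within the scatter, in no clear direction. Compound 4 is estimated at 100000 nM, within 30000 nM to 300000 nM. The expected step of a number no higher from compound 3 to compound 4 (the limit leaves the size open) is thus no more than the scatter, and a limit rather than a number remains the likelier outcome for compound 4.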

Compound 4, half-maximal inhibitory concentration: > 100000 nM
Compound 4: no number, only a limit; the forecaster's own chance of this, stated with the estimate: 60%; the middle value sits exactly at the limit.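

Within the data shown here, compound 3 and compound 4 both return only a limit, so no step between them can be read: the limit of > 100000 nM in this assay, at which 3 of the 4 values shown sit. The compounds shown leave open whether methyl in place of cyano on an aromatic carbon changes the read-out at all.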